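Changing the Side Chain of Compound 3

The compounds below may be only part of what the source reports. "The series", "measured", "known", "first", "only" and "open" are said of these compounds alone.

In an in vitro ADME assay on microsomes from liver (Homo sapiens) for metabolic stability, tested at 5 uM (on this read-out higher numbers stand for a longer-lived compound and lower numbers for a shorter-lived compound), compound 3 `CCC(C)CCn1nc(-c2cccs2)c(O)c(C2=NS(=O)(=O)c3cc(NS(C)(=O)=O)ccc3N2)c1=O` gives > 1 h as a limit of the assay and not a number. Compound 1 `CC(C)CCn1nc(C2=CCCC2)c(O)c(C2=NS(=O)(=O)c3cc(NS(C)(=O)=O)ccc3N2)c1=O` gives 0.933 h and compound 2 `C/C(=C\c1nn(CCC(C)C)c(=O)c(C2=NS(=O)(=O)c3cc(NS(C)(=O)=O)ccc3N2)c1O)C(F)(F)F` gives 0.167 h on the same read-out. Compound 4 `CS(=O)(=O)Nc1ccc2c(c1)S(=O)(=O)N=C(c1c(O)c(-c3cccs3)nn(CC3CC3)c1=O)N2` differs from compound 3 in one place, cyclopropyl in place of 2-methylbutyl on a saturated chain carbon bound to an aromatic nitrogen with cyclopropyl in place of 2-methylbutyl on a saturated chain carbon bound to an aromatic nitrogen. For the measured compounds named here, the only measured step of a 5.6-fold lower number from compound 1 to compound 2 (0.75 log units; beyond the scatter) lies beyond the scatter, but it sits on an aromatic carbon and not on this chain. Going by the values given here, with no measured step at this place, the expected change in this assay is a step that the limit leaves unreadable from compound 3 to compound 4 with nothing expected beyond the scatter. For compound 4 the estimated half-life is 1.2 h with an expected range from 0.5 h to 3 h in this measurement.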

Compound 4, half-life: > 1 h
Compound 4: no number, only a limit; the forecaster's own chance of this, stated with the estimate: 55%; the middle value lies beyond the limit too.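

Compound 4 gives > 1 h as a limit and not a number. For the compounds shown here, compound 3 also stands at a limit, so no step from compound 3 to compound 4 can be read: the limit of > 1 h in this assay, at which 2 of the 4 values shown sit.

The compounds shown leave open how far either half-life reaches past that limit, and whether cyclopropyl in place of 2-methylbutyl changes it at all.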